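Swapping the Sulfonyl Aryl Group in a Receptor Binding Series

A few compounds are considered here, and "the series" means these few. Any claim that something is new, unique, unknown or untested is made for them only; others in the source may bear on it.

Measured compounds:
Compound 1, `COc1cccc(Oc2c(NS(=O)(=O)c3ccc(C(C)(C)C)cc3)ncnc2OCCOCc2ccccc2)c1`, gives 170 nM in an assay on cells (Endothelial cell) for binding affinity to Endothelin-1 receptor (Sus scrofa); a lower number here means a stronger inhibitor, a higher number a weaker inhibitor.
Compound 2, `COc1cccc(Oc2c(NCCOc3ncccn3)ncnc2NS(=O)(=O)c2ccc(C(C)(C)C)cc2)c1`, gives 6.2 nM in this assay.
Compound 3, `CCC(C)(C)c1ccc(S(=O)(=O)Nc2ncnc(OCCOc3ncc(Br)cn3)c2-c2ccc(C)cc2)cc1`, gives < 0.001 nM in this assay.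

Among the measured compounds shown here, compound 3 stands at a limit rather than at a number: its reading is the limit of < 0.001 nM in this assay, at which 1 of the 3 values shown sits, so only a bound on its binding is known, and it is the only one of the three compounds at that bound.

Compound 4, `Cc1ccc(-c2c(NS(=O)(=O)c3cccs3)ncnc2OCCOc2ncc(Br)cn2)cc1`, differs from compound 3 in one place: thiophen-2-yl in place of 4-(1,1-dimethylpropyl)phenyl on a sulfonyl sulfur. For the measured compounds named here, the single measured step, a 27-fold lower number from compound 1 to compound 2 (1.44 log units; beyond the scatter), concerns a group on an aromatic carbon of the core and not the sulfonyl sulfur, so no measured step bears on this change. The expectation for compound 4 therefore rests on the limit of compound 3 alone, and the direction is uncertain, with a higher number judged more likely than a lower one.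

Compound 4 is estimated to give 0.5 nM in this assay, expected to lie between 0.001 nM and 50 nM. That corresponds to an expected step of an at least 500-fold higher number from compound 3 to compound 4 (2.69 log units; beyond the scatter).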

Compound 4, half-maximal inhibitory concentration: 3.1 nM
Estimate against measurement, compound 4: 6.2-fold (0.79 log units) below, and the stated range covers the measured number.
By their numbers in this assay, from the lowest: compounds 4 and 2 (each within the scatter of the next); then compound 1. At a limit, below all of these: compound 3.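

Among the compounds shown here, until now, no measured step touched the group on the sulfonyl sulfur, and here thiophen-2-yl in place of 4-(1,1-dimethylpropyl)phenyl gives an at least 3100-fold higher number from compound 3 to compound 4 (3.49 log units; beyond the scatter). This position therefore matters strongly in this assay, even though compound 4 still gives a low number of 3.1 nM. The true size of the step stays unknown, because the reading for compound 3 is only a limit: the limit of < 0.001 nM in this assay, at which 1 of the 4 values shown sits.

The change replaces a six-membered carbon ring and its 1,1-dimethylpropyl group with a five-membered ring containing sulfur in a single move, so the compounds shown cannot tell which part of that swap accounts for the step. A plain phenyl or a 4-methylphenyl on the sulfonyl sulfur, with the rest of compound 3 kept, would help separate the contribution of the ring from that of its 1,1-dimethylpropyl group.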